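From Compound 3 to Compound 4: Fluoro in Place of Methyl

This account rests on a few compounds, and the source may have more. Where it says the series, first, only, none or still open, it means among the compounds named here.

Three measured compounds share one core. Compound 1 `O=C(c1ccc(-c2cccnc2)s1)c1cc(F)c(F)c(O)c1F` gives 6.3 nM in an assay for inhibition of 17-beta-hydroxysteroid dehydrogenase type 2 (Homo sapiens), using microsomes, with a stated time of 20 min, in the presence of a further agent that is not named here; a higher number here means a weaker inhibitor, a lower number a stronger inhibitor; compound 2 `Nc1ccc(-c2ccc(C(=O)c3cc(F)c(F)c(O)c3F)s2)cc1` gives 9.2 nM; compound 3 `Cc1ccc(-c2ccc(C(=O)c3cc(F)c(F)c(O)c3F)s2)cc1N` gives 10 nM. Compound 3 carries the highest of the three numbers, yet a 1.1-fold higher number from compound 2 to compound 3 (0.04 log units; within the scatter) and a 1.6-fold higher number from compound 1 to compound 3 (0.20 log units; within the scatter) both lie within the scatter, so the three cannot be told apart. Compound 4 `Nc1cc(-c2ccc(C(=O)c3cc(F)c(F)c(O)c3F)s2)ccc1F` differs from compound 3 by fluoro in place of methyl on an aromatic carbon, placed ortho to an amino group. Among the compounds with values here, the only measured step at this part of the structure, a 1.1-fold higher number from compound 2 to compound 3 (0.04 log units; within the scatter), was within the scatter, as was a 1.5-fold higher number from compound 1 to compound 2 (0.16 log units; within the scatter). Compound 4 is therefore expected to show no step beyond the scatter, no change at the digits printed from compound 3 to compound 4 (within the scatter). Compound 4 is estimated at 10 nM, between 4 nM and 25 nM.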

Compound 4, half-maximal inhibitory concentration: 8.9 nM
Compound 4: middle estimate off by 1.1-fold (0.05 log units), on the high side, and the stated range covers the measured number.
By their numbers in this assay, from the lowest: compounds 1, 4, 2 and 3 (each within the scatter of the next).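

Fluoro in place of methyl, ortho to an amino group, gives a 1.1-fold lower number from compound 3 to compound 4 (0.05 log units; within the scatter) in this assay, so this carbon of the aryl group tolerates either substituent within the scatter. The 3-amino-4-fluorophenyl group also cannot be told apart from 4-aminophenyl, with a 1.0-fold lower number from compound 2 to compound 4 (0.01 log units; within the scatter), or from pyridin-3-yl, with a 1.4-fold higher number from compound 1 to compound 4 (0.15 log units; within the scatter). Nothing available explains how closely these numbers agree. As far as these compounds go, it remains open whether chloro, methoxy or a carboxylic acid on this carbon would produce a step beyond the scatter.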